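Swapping the Aryl Group on the Sulfonyl Sulfur

This account rests on a few compounds, and the source may have more. Where it says the series, first, only, none or still open, it means among the compounds named here.

Of the compounds shown here, three built on one shared core have been tested in a functional assay on KOPN-8 cells (Homo sapiens) for antiproliferative activity, with a stated time of 72 h; a lower number here means that less compound is needed, a higher number that more compound is needed for the effect. Compound 1 `COc1ccc(-c2cc(=O)c3c(OC)cc(OC)cc3n2S(=O)(=O)c2ccc(C=O)cc2)cc1` gives > 34400 nM in this assay, which is a limit of the assay rather than a number. Compound 2 `COc1ccc(-c2cc(=O)c3c(OC)cc(OC)cc3n2S(=O)(=O)c2ccc(C#N)cc2)cc1` gives > 17200 nM, again a limit. Compound 3 `COc1ccc(-c2cc(=O)c3c(OC)cc(OC)cc3n2S(=O)(=O)c2c(F)c(F)c(F)c(F)c2F)cc1` gives > 34400 nM, also a limit. Compound 3 sits at the limit of > 34400 nM in this assay, at which 2 of the 3 values shown sit, while compound 2 sits at the limit of > 17200 nM in this assay, at which 1 of the 3 values shown sits. All three values are limits, so the steps a step that the two limits leave unreadable from compound 1 to compound 2, a step that the two limits leave unreadable from compound 1 to compound 3 and a step that the two limits leave unreadable from compound 2 to compound 3 cannot be sized, and none of them shows whether changing the group on the sulfonyl sulfur matters at all.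

Compound 4 `COc1ccc(-c2cc(=O)c3c(OC)cc(OC)cc3n2S(=O)(=O)c2cc(Cl)cc(Cl)c2O)cc1` differs from compound 3 by 3,5-dichloro-2-hydroxyphenyl in place of 2,3,4,5,6-pentafluorophenyl on a sulfonyl sulfur. No measured step bears on this change in a readable way, so the numbers shown give no direction to expect. The working expectation is simply that compound 4 stays near where compound 3 stands. Compound 4 is therefore expected to give an estimated 30000 nM in this assay. Its expected range runs from 4000 nM to 100000 nM. This corresponds to an expected step of an at least 1.1-fold lower number from compound 3 to compound 4 (0.05 log units; that floor lies within the scatter).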

Compound 4, half-maximal effective concentration: > 37900 nM
Compound 4 gave a limit, no number (the forecaster's own chance of this, stated with the estimate: 70%); at least 1.2-fold (0.10 log units) between middle value and limit.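

In this assay compound 4 gives > 37900 nM, again a limit and not a number, so its steps to compound 1, compound 2 and compound 3 cannot be read. The compounds shown leave open whether the aryl group on the sulfonyl sulfur affects the result in this assay at all.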